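The source may report more compounds than this note shows. Statements on the series, on what has been measured and on what is new or still open speak of the compounds shown alone.

Measured compounds:
- Compound 1, `CC(=O)/C(=N\O)c1ccc(Sc2cc(F)cc(C3CCOCC3)c2)cc1`: 850 nM in a functional assay (blood) for inhibition, with Homo sapiens as the target; a higher number here means a weaker inhibitor, a lower number a stronger inhibitor
- Compound 2, `COC1(c2csc(Sc3ccc4c(c3)CC/C4=N\OCC#N)c2)CCOCC1`: 40 nM in this assay
- Compound 3, `CO[C@]1(c2cc(F)cc(Sc3ccc(/C(C)=N/O)cc3)c2)CCO[C@@H](C)C1`: 40 nM in this assay

Among these three, compound 1 stands at the highest number, and the gap to each of the other two lies beyond the scatter. Compound 2 and compound 3 sit at the same number, so nothing can be said about their order.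

The unmeasured compound 4, `CO/N=C(\C)c1ccc(Sc2cc(F)cc(C3CCOCC3)c2)cc1`, keeps the core of compound 1 and differs from it at a single point: a group of 5 heavy atoms (3 carbon, 1 nitrogen, 1 oxygen; no ring) in place of a group of 6 heavy atoms (3 carbon, 1 nitrogen, 2 oxygen; no ring), on an aromatic carbon. The group that leaves carries one hydrogen-bond donor and three acceptors, the group that enters carries no donor and two acceptors; the place is on an aromatic carbon, para to a large group.

Among the measured compounds shown here, no measured pair differs in exactly this way, so the size of the step has to be guessed. Compound 2 and compound 3, which carry oxime-type groups without the extra carbonyl, both give much lower numbers than compound 1, which suggests a move toward lower numbers for compound 4, though with a wide range. The step from compound 1 to compound 4 is expected to be a 3.4-fold lower number from compound 1 to compound 4 (0.53 log units; beyond the scatter). Compound 4 is estimated at 250 nM in this assay, with a range from 60 nM to 1000 nM.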

Compound 4, half-maximal inhibitory concentration: 110 nM
Compound 4: middle estimate off by 2.3-fold (0.36 log units), on the high side, within the range that was stated.
By their numbers in this assay, from the lowest: compounds 2 and 3 (each within the scatter of the next); then compound 4; then compound 1.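

Read in this assay, the exchange of the group of 6 heavy atoms for the group of 5 heavy atoms, on an aromatic carbon para to a large group, gives a 7.7-fold lower number from compound 1 to compound 4 (0.89 log units; beyond the scatter), and this is the only single-place comparison among the compounds shown. It shows that this place on the core of compound 1 responds to the change by more than the scatter, and that the number falls as the hydrogen-bond donor, one acceptor-bearing oxygen and one double bond outside aromatic rings leave together. These differences travel in one exchange. This single step cannot apportion the shift among them, and nothing measured here explains it.

The compounds shown leave open how far the trend at this place extends, for instance whether a longer chain, an amine or a carboxylic acid there would move the number further in either direction. Among the compounds shown here, they also leave open whether the same exchange gives a step of similar size on a different core, since no other pair differing in exactly this way is available.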